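The source may report more compounds than this note shows. Statements on the series, on what has been measured and on what is new or still open speak of the compounds shown alone.

For the measured compounds named here, in a functional assay on HL-60 cells (Homo sapiens) for antiproliferative activity, with a stated time of 72 h (on this read-out higher numbers stand for weaker inhibition and lower numbers for stronger inhibition), compound 1 (`COc1ccc(CNc2ncnc3c2ncn3[C@@H]2O[C@H](CO)[C@@H](O)[C@H]2O)c(OC)c1`) gives 39000 nM as the only number available. Compound 2 (`OC[C@H]1O[C@@H](n2cnc3c(NCc4cccc(O)c4O)ncnc32)[C@H](O)[C@@H]1O`) has no place on this scale, since its entry reads "not determined" (no result reported) and offers no single number. Compound 3 (`Cc1ccc(O)c(CNc2ncnc3c2ncn3[C@@H]2O[C@H](CO)[C@@H](O)[C@H]2O)c1`) differs from compound 2 by 2-hydroxy-5-methylphenyl in place of 2,3-dihydroxyphenyl on a saturated chain carbon bound to a nitrogen on an aromatic ring with 2-hydroxy-5-methylphenyl in place of 2,3-dihydroxyphenyl on a saturated chain carbon bound to a nitrogen on an aromatic ring. Going by the values given here, with no measured step to go on, compound 3 is expected in this assay to stay close to compound 1 at 39000 nM with no step beyond the scatter. For compound 3 the estimated value is 30000 nM within an expected range from 8000 nM to 100000 nM on this read-out.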

Compound 3, half-maximal inhibitory concentration: 15000 nM
The estimate for compound 3 lay 2.0-fold (0.30 log units) above the measured number, within the range that was stated.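

In this assay, for the compounds shown here, the change from 2,4-dimethoxyphenyl to 2-hydroxy-5-methylphenyl on a saturated chain carbon bound to a nitrogen on an aromatic ring gives a 2.6-fold lower number from compound 1 to compound 3 (0.41 log units; beyond the scatter) as a modest step, the first measured step at this place. The change from compound 2 to compound 3 cannot be read, as compound 2 has no number. Nothing available accounts for the step. As far as these compounds go, two things change at once between these groups, so the shares of the hydroxy and the methyl stay open. Also open, from the compounds shown here alone, is how an amine or a carboxylic acid on this phenyl ring would read.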